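This account rests on a few compounds, and the source may have more. Where it says the series, first, only, none or still open, it means among the compounds named here.

Compound 1 `Cc1cc2c(c(Oc3cccc(NS(=O)(=O)c4ccc(Cl)cc4)c3)n1)C(=O)N(C1CC1)C2=O`: 15 nM
Compound 2 `Cc1cc2c(c(Oc3cccc(NS(=O)(=O)c4ccc(Cl)cc4)c3)n1)C(=O)NC2=O`: 121 nM
Compound 3 `Cc1cc2c(c(Oc3cccc(NS(=O)(=O)c4ccc(Cl)cc4)c3)n1)C(=O)N(C(C)C)C2=O`: 13 nM

In a functional assay on HEK293 cells for agonist activity at Glucose-dependent insulinotropic receptor (Homo sapiens), read by cAMP accumulation, with a stated time of 30 min (a higher number here means that more compound is needed for the effect, a lower number that less compound is needed), compound 3 has the lowest number of the three, though its gap to compound 1 lies within the scatter a 1.2-fold lower number from compound 1 to compound 3 (0.06 log units; within the scatter). Compound 2, with only a hydrogen on the amide-type nitrogen in the ring, stands apart a 9.3-fold lower number from compound 2 to compound 3 (0.97 log units; beyond the scatter). Compound 4 `Cc1cc2c(c(Oc3cccc(NS(=O)(=O)c4ccc(Cl)cc4)c3)n1)C(=O)N(C1CCCC1)C2=O` is the next step: cyclopentyl in place of isopropyl on an amide-type nitrogen in a ring. Among the compounds with values here, the steps that bear on this place show that a hydrogen costs much an 8.1-fold higher number from compound 1 to compound 2 (0.91 log units; beyond the scatter), while exchanging one small carbon group for another changes little. Because compound 3 gives 13 nM, compound 4 is expected to stay near it, with a step of a 1.2-fold higher number from compound 3 to compound 4 (0.06 log units; within the scatter). The estimate for compound 4 is 15 nM, in a range from 5 nM to 45 nM.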

Compound 4, half-maximal effective concentration: 69 nM
Compound 4: the middle estimate sits 4.6-fold (0.66 log units) below what was measured; the whole stated range lies below it.
By their numbers in this assay, from the lowest: compounds 3 and 1 (each within the scatter of the next); then compounds 4 and 2 (each within the scatter of the next).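

On the amide-type nitrogen in a ring, not every carbon group serves equally in this assay: cyclopentyl gives a clear loss against isopropyl (a 5.3-fold higher number from compound 3 to compound 4 (0.72 log units; beyond the scatter)) and against cyclopropyl (a 4.6-fold higher number from compound 1 to compound 4 (0.66 log units; beyond the scatter)). Cyclopentyl also cannot be told apart from hydrogen at this place (a 1.8-fold lower number from compound 2 to compound 4 (0.24 log units; within the scatter)), so the benefit of a carbon group depends on which group it is. Nothing measured here explains this loss.

Going by these compounds, whether cyclobutyl, a longer chain such as butyl, or an amine at this nitrogen would keep the number near that of compound 3 remains open.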